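A few compounds are considered here, and "the series" means these few. Any claim that something is new, unique, unknown or untested is made for them only; others in the source may bear on it.

Going by the values given here, compound 1 `COc1ccc(C(=O)Nc2cccc(-c3oc4cc(-c5ccc(F)cc5)ccc4c(=O)c3O)c2)cc1` is one of two compounds measured in a functional assay on MCF7 cells (Homo sapiens) for antiproliferative activity, read by CCK-8 assay, with a stated time of 72 h (a higher number here means a weaker inhibitor, a lower number a stronger inhibitor), where compound 1 gives 6250 nM. That is the highest of the two numbers seen; the nearest is compound 2 `O=C(Nc1cccc(-c2oc3cc(-c4ccc(F)cc4)ccc3c(=O)c2O)c1)c1ccc(Cl)nc1`, which in this assay gives 2890 nM. Among the compounds with values here, the single measured step, a 2.2-fold lower number from compound 1 to compound 2 (0.33 log units; beyond the scatter), came with 6-chloropyridin-3-yl in place of 4-methoxyphenyl on a carbonyl carbon.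

Compound 3 `O=C(Nc1cccc(-c2oc3cc(-c4ccc(F)cc4)ccc3c(=O)c2O)c1)c1cc(F)cc(F)c1` has not yet been measured. It differs from compound 1 as 3,5-difluorophenyl in place of 4-methoxyphenyl on a carbonyl carbon. The step to compound 2 bears on this only loosely: both exchanges remove the same 4-methoxyphenyl from the carbonyl carbon, and that one exchange gave the step shown. Since 3,5-difluorophenyl is a different group, only a small lowering is expected, possibly none beyond the scatter. For compound 3 the estimate in this assay is 4000 nM, with a range from 2000 nM to 8000 nM, which means an expected step of a 1.6-fold lower number from compound 1 to compound 3 (0.19 log units; within the scatter).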

Compound 3, half-maximal inhibitory concentration: 2490 nM
The estimate for compound 3 lay 1.6-fold (0.21 log units) above the measured number; low and high end bracket the measured number.
By their numbers in this assay, from the lowest: compounds 3 and 2 (each within the scatter of the next); then compound 1.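

In this assay, a second group in place of the 4-methoxyphenyl on the carbonyl carbon also gives a lower number (a 2.5-fold lower number from compound 1 to compound 3 (0.40 log units; beyond the scatter)), so the change seen with compound 2 is no longer a single case. The 3,5-difluorophenyl and 6-chloropyridin-3-yl groups cannot be told apart at this position (a 1.2-fold lower number from compound 2 to compound 3 (0.06 log units; within the scatter)), which shows that a ring of carbon only can give a number in the same range as the ring holding nitrogen. Nothing measured here explains either step.

The compounds shown leave open whether a plain phenyl would also give a lower number than the 4-methoxyphenyl. They also leave open how an amine, a carboxylic acid or a saturated cyclohexyl ring would fare on the same carbonyl carbon.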